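Shifting the methoxy group: working notes on Vero tolerance

This account rests on a few compounds, and the source may have more. Where it says the series, first, only, none or still open, it means among the compounds named here.

Of the compounds shown here, three have been measured in an ADME assay on Vero cells (Chlorocebus sabaeus) for cytotoxicity, read by MTT assay, with a stated time of 72 h (a lower number here means that less compound is tolerated, a higher number that more compound is tolerated), and each gave only a limit of the assay, not a number. Compound 1 `COC(=O)c1cc(-c2cccc(NC(=O)c3ccc(/C=C/C(=O)c4cccc(Cl)c4)cc3)c2)on1` carries a 3-chlorophenyl on the carbonyl carbon; in this assay compound 1 gives > 2.5 ug/mL, which is a limit. Compound 2 `COC(=O)c1cc(-c2cccc(NC(=O)c3ccc(/C=C/C(=O)c4cccc([N+](=O)[O-])c4)cc3)c2)on1` has nitro in place of chloro on an aromatic carbon; in this assay compound 2 gives > 40 ug/mL, again a limit. Compound 3 `COC(=O)c1cc(-c2cccc(NC(=O)c3ccc(/C=C/C(=O)c4ccc(OC)cc4)cc3)c2)on1` has 4-methoxyphenyl in place of 3-chlorophenyl on a carbonyl carbon; in this assay compound 3 gives > 10 ug/mL, also a limit. The steps between them, a step that the two limits leave unreadable from compound 1 to compound 2, a step that the two limits leave unreadable from compound 1 to compound 3 and a step that the two limits leave unreadable from compound 2 to compound 3, therefore carry no readable size. Compound 3 stands at the limit of > 10 ug/mL in this assay, at which 1 of the 3 values shown sits, while the other two values sit at the limit of > 2.5 ug/mL in this assay, at which 1 of the 3 values shown sits, and (the limit of > 40 ug/mL in this assay, at which 1 of the 3 values shown sits).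

Compound 4 `COC(=O)c1cc(-c2cccc(NC(=O)c3ccc(/C=C/C(=O)c4ccccc4OC)cc3)c2)on1` differs from compound 3 by 2-methoxyphenyl in place of 4-methoxyphenyl on a carbonyl carbon. Among the measured compounds shown here, no measured step bears on this change; the two steps that involve the 4-methoxyphenyl, a step that the two limits leave unreadable from compound 1 to compound 3 and a step that the two limits leave unreadable from compound 2 to compound 3, give no size at all. The expected step that the limit leaves unreadable from compound 3 to compound 4 is therefore none beyond the scatter, with a limit the most likely outcome. Compound 4 is estimated at 15 ug/mL, within a range from 5 ug/mL to 50 ug/mL.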

Compound 4, half-maximal cytotoxic concentration: > 40 ug/mL
Compound 4: a limit, no number; the forecaster's own chance of this, stated with the estimate: 70%; middle value at least 2.6-fold (0.42 log units) from the limit.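

Compound 4 gives only a limit in this assay, as do compound 1, compound 2 and compound 3, so none of the steps to compound 4 can be read. The compounds shown leave open whether 2-methoxyphenyl in place of 4-methoxyphenyl changes the half-maximal cytotoxic concentration in this assay at all.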